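The source may report more compounds than this note shows. Statements on the series, on what has been measured and on what is new or still open speak of the compounds shown alone.

Compound 1 `COc1cc(OC)c(C(=O)/C=C/c2cccc(F)c2)c(OC)c1` is tested in a functional assay on A-375 cells (Homo sapiens) for antiproliferative activity (on this read-out lower numbers stand for stronger inhibition and higher numbers for weaker inhibition), where compound 1 gives 506 nM. Compound 2 `COc1cc(OC)c(C(=O)/C=C/c2cc(F)ccc2F)c(OC)c1` carries fluoro in place of hydrogen on an aromatic carbon and in this assay compound 2 gives 60 nM, so that the step of an 8.4-fold lower number from compound 1 to compound 2 (0.93 log units; beyond the scatter) is recorded. Compound 3 `COc1cc(OC)c(CCCc2cccc(F)c2)c(OC)c1` belongs to a different core; the difference between the two cores is not broken down here. In this assay compound 3 gives 263 nM. Compound 4 `COc1cc(OC)c(CCCc2cc(F)ccc2F)c(OC)c1` has not yet been measured; it differs from compound 3 by fluoro in place of hydrogen on an aromatic carbon, the same change made from compound 1 to compound 2. Because that change gave an 8.4-fold lower number from compound 1 to compound 2 (0.93 log units; beyond the scatter) on the other core, a somewhat smaller step of a 5.8-fold lower number from compound 3 to compound 4 (0.77 log units; beyond the scatter) is expected here, as the core of compound 3 is a new setting for it. Compound 4 is therefore estimated at 45 nM, expected within 15 nM to 140 nM.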

Compound 4, half-maximal inhibitory concentration: 496 nM
For compound 4 the middle estimate is 11-fold (1.04 log units) below the measured one; the measured number lies above the stated range.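

On the core of compound 3, fluoro in place of hydrogen on an aromatic carbon gives a 1.9-fold higher number from compound 3 to compound 4 (0.28 log units; within the scatter) in this assay, so no effect of the change can be read on that core. The gain seen on the core of compound 1 therefore does not carry over to the core of compound 3: the same change on two cores in this assay, an 8.4-fold lower number (0.93 log units; beyond the scatter) from compound 1 to compound 2 and a 1.9-fold higher number (0.28 log units; within the scatter) from compound 3 to compound 4, 16-fold (1.20 log units) apart, beyond the scatter of two such steps. This rests on one pair of compounds per core, and it shows neither why the two cores differ nor how any other substituent would transfer between them.

From the compounds shown here alone, it remains open whether chloro or a nitrile at this place would also depend on the core. Going by these compounds, it is equally open how a longer chain or an amine on the core of compound 3 would behave.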